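Three analogues and a proline ester on the shared core

The source may hold more compounds than are shown below. What is called first, only, known or untested is meant among the compounds shown, and "the series" means these compounds.

Compound 1, `COc1cc(-c2nc3ccccc3s2)ccc1OCC(=O)NNC(=O)CCl`, gives 780 nM in a functional assay on MCF7 cells (Homo sapiens) for inhibition, read by MTT assay, with a stated time of 3 days; a higher number here means a weaker inhibitor, a lower number a stronger inhibitor.
Compound 2, `CC[C@H](C)[C@@H](NCC(=O)NNC(=O)COc1ccc(-c2nc3ccccc3s2)cc1OC)C(=O)O`, gives 1790 nM in this assay.
Compound 3, `COc1cc(-c2nc3ccccc3s2)ccc1OCC(=O)NNC(=O)CN(C(C)=O)[C@@H](CS)C(=O)O`, gives 1750 nM in this assay.

Compound 3 has the second highest number of the three. Its nearest neighbour is compound 2, and the two lie within the scatter of each other, as a 1.0-fold lower number from compound 2 to compound 3 (0.01 log units; within the scatter) shows. Compound 1 sits furthest away, as a 2.2-fold higher number from compound 1 to compound 3 (0.35 log units; beyond the scatter) shows.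

Compound 4, `CCOC(=O)[C@@H]1CCCN1CC(=O)NNC(=O)COc1ccc(-c2nc3ccccc3s2)cc1OC`, is not yet measured. It differs from compound 3 in one place: 2-(ethoxycarbonyl)pyrrolidin-1-yl in place of acetyl(1-carboxy-2-sulfanylethyl)amino on a saturated chain carbon bound to a carbonyl carbon.

Two measured steps speak to this change. Both replacements of the chloro group with an amino-acid-derived substituent on the saturated chain carbon bound to a carbonyl carbon gave modest rises, a 2.3-fold higher number from compound 1 to compound 2 (0.36 log units; beyond the scatter) and a 2.2-fold higher number from compound 1 to compound 3 (0.35 log units; beyond the scatter). Exchanging one such substituent for another gave no step beyond the scatter, a 1.0-fold lower number from compound 2 to compound 3 (0.01 log units; within the scatter). Compound 4 carries a third substituent of this kind, so compound 4 is expected to show no step beyond the scatter in this assay, at most a 1.2-fold lower number from compound 3 to compound 4 (0.07 log units; within the scatter). The estimate for compound 4 is therefore 1500 nM, within a range from 700 nM to 3500 nM.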

Compound 4, half-maximal inhibitory concentration: 770 nM
Estimate against measurement, compound 4: 1.9-fold (0.29 log units) above; the range from low to high includes it.
By their numbers in this assay, from the lowest: compounds 4 and 1 (each within the scatter of the next); then compounds 3 and 2 (each within the scatter of the next).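

In this assay, the place on a saturated chain carbon bound to a carbonyl carbon proves less indifferent to amino-acid-derived substituents than the earlier exchange suggested, since 2-(ethoxycarbonyl)pyrrolidin-1-yl gives a 2.3-fold lower number from compound 3 to compound 4 (0.36 log units; beyond the scatter) and a 2.3-fold lower number from compound 2 to compound 4 (0.37 log units; beyond the scatter) as steps beyond the scatter. The rise on leaving chloro is also not general, as this group gives a 1.0-fold lower number from compound 1 to compound 4 (0.01 log units; within the scatter) and so stands level with chloro, with compound 2 and compound 3 showing the rise and compound 4 going against it. The group that enters brings a five-membered non-aromatic ring and 0 hydrogen-bond donors, where the group that leaves compound 3 has no ring and 2 hydrogen-bond donors, but no measurement here ties the step to either feature or to any other cause.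

The compounds shown leave open whether the pyrrolidine ring or the ethyl ester goes with the lower number. A free carboxylic acid on the same pyrrolidine ring, or an ethyl ester on the open-chain (1-carboxy-2-methylbutyl)amino group, would separate the two.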